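Carbamate to urea on the acylsulfonamide of compound 2

This account rests on a few compounds, and the source may have more. Where it says the series, first, only, none or still open, it means among the compounds named here.

Going by the values given here, compound 2 `CC(C)Cc1cc(-c2cccc(Cn3ccnc3)c2)c(S(=O)(=O)NC(=O)OCC2CC2)s1` holds the lowest of the two numbers so far: in an assay on HEK293 cells for displacement of a labelled ligand from Type-2 angiotensin II receptor (Homo sapiens), read by scintillation counting, with a stated time of 240 min (a lower number here means a stronger inhibitor, a higher number a weaker inhibitor), compound 2 gives 140 nM. Compound 1 `CCC(C)OC(=O)NS(=O)(=O)c1sc(CC(C)C)cc1-c1cccc(Cn2ccnc2)c1` gives 440 nM in this assay, and the step of a 3.1-fold lower number from compound 1 to compound 2 (0.50 log units; beyond the scatter) is the only measured one. Compound 3 `CCN(CC)C(=O)NS(=O)(=O)c1sc(CC(C)C)cc1-c1cccc(Cn2ccnc2)c1` differs from compound 2 by diethylamino in place of cyclopropylmethoxy on a carbonyl carbon. Among the compounds with values here, no measured step varies this part; the single step from compound 1 to compound 2 swaps one alkoxy group for another and bears on it only loosely. A modest step in either direction, or none beyond the scatter, is plausible. Compound 3 is therefore estimated at 300 nM in this assay, range 80 nM to 1200 nM. The expected step is a 2.1-fold higher number from compound 2 to compound 3 (0.33 log units; beyond the scatter).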

Compound 3, inhibition constant: 2300 nM
Estimate against measurement, compound 3: 7.7-fold (0.88 log units) below; the measured number lies above the stated range.
By their numbers in this assay, from the lowest: compound 2; then compound 1; then compound 3.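

Diethylamino on the carbonyl carbon gives a higher number in this assay than either alkoxy group: a 16-fold higher number from compound 2 to compound 3 (1.22 log units; beyond the scatter) against cyclopropylmethoxy and a 5.2-fold higher number from compound 1 to compound 3 (0.72 log units; beyond the scatter) against sec-butoxy. This position therefore responds to more than the exchange of one alkoxy group for another, and with compound 3 the series now includes a large step. Nothing available explains the loss.

The compounds shown do not separate the change from oxygen to nitrogen from the change in the alkyl groups. Cyclopropylmethylamino on the same carbonyl carbon would bear on that question.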